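Swapping 4-methoxyphenyl for 1H-pyrrol-2-yl on a carbonyl carbon

This account rests on a few compounds, and the source may have more. Where it says the series, first, only, none or still open, it means among the compounds named here.

- Compound 1 `O=C1Nc2ccc(F)cc2/C1=C\C(=O)c1ccc(C2CCCCC2)cc1` gives 2840 nM
- Compound 2 `O=C1Nc2ccc(F)cc2/C1=C\C(=O)c1cccs1` gives 8780 nM
- Compound 3 `COc1ccc(C(=O)Nc2ccc3c(c2)/C(=C/Nc2cccc(N4CCN(C)CC4)c2)C(=O)N3)cc1` gives 1780 nM

In a functional assay on HepG2 cells (Homo sapiens) for inhibition, read by sulforhodamine B assay, with a stated time of 3 days (a higher number here means a weaker inhibitor, a lower number a stronger inhibitor), compound 3 (1780 nM) sits within the usual scatter of compound 1 (2840 nM), while compound 2 (8780 nM) carries a higher number, beyond the scatter from compound 3.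

Compound 4 `CN1CCN(c2cccc(N/C=C3\C(=O)Nc4ccc(NC(=O)c5ccc[nH]5)cc43)c2)CC1` is the next to be read. It has 1H-pyrrol-2-yl in place of 4-methoxyphenyl on a carbonyl carbon. Among the measured compounds shown here, no two measured compounds differ in one place, so the data offer no direct guide to this change. The estimate therefore starts from compound 3 (1780 nM), and no step beyond the scatter is expected in this assay (a 1.4-fold higher number from compound 3 to compound 4 (0.15 log units; within the scatter)). Compound 4 is estimated at 2500 nM (range 800 nM to 8000 nM).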

Compound 4, half-maximal inhibitory concentration: 5370 nM
Estimate against measurement, compound 4: 2.1-fold (0.33 log units) below; the range from low to high includes it.
By their numbers in this assay, from the lowest: compounds 3, 1, 4 and 2 (each within the scatter of the next, the first and the last beyond it).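

Among the compounds shown here, measured in this assay, the swap of 4-methoxyphenyl for 1H-pyrrol-2-yl on this carbonyl carbon gives a 3.0-fold higher number from compound 3 to compound 4 (0.48 log units; beyond the scatter) and is the first direct reading of this position, which proves sensitive to the group it carries. The change replaces the ring and removes the methoxy group in one step, so this single pair cannot separate the two. No measurement shown bears on the cause of the step. On these data alone, it remains open how a plain phenyl or a 1H-imidazol-2-yl group on this carbonyl carbon would read.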